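The compounds below may be only part of what the source reports. "The series", "measured", "known", "first", "only" and "open" are said of these compounds alone.

Working notes on the series. The compounds share the core of compound 1 `O=C1c2ccccc2N(Cc2ccc(Cl)cc2)S(=O)(=O)N1Cc1ccccc1`; compound 2 `O=C1c2ccccc2N(Cc2ccccc2)S(=O)(=O)N1Cc1ccccc1` and compound 3 `C#CCOCN1c2ccccc2C(=O)N(Cc2ccccc2)S1(=O)=O` differ from it at the saturated chain carbon bound to a sulfonamide nitrogen in a ring. In a functional assay on HEL cells (Homo sapiens) for inhibition (on this read-out lower numbers stand for higher toxicity in this test and higher numbers for lower toxicity in this test), compound 1 gives > 200000 nM, which is a limit of the assay and not a number. Compound 2 gives > 200000 nM, likewise a limit. Compound 3 gives > 140000 nM, again only a limit, so compound 3 stands at a limit as do the other two values. The steps a step that the two limits leave unreadable from compound 1 to compound 3 and a step that the two limits leave unreadable from compound 2 to compound 3 concern this position, and a step that the two limits leave unreadable from compound 1 to compound 2; none yields a readable size, with the limit of > 140000 nM in this assay, at which 1 of the 3 values shown sits, and the limit of > 200000 nM in this assay, at which 2 of the 3 values shown sit, the only marks. Compound 4 `O=C1c2ccccc2N(COCc2ccccc2)S(=O)(=O)N1Cc1ccccc1` differs from compound 3 by phenyl in place of ethynyl on a saturated chain carbon bound to an oxygen on a saturated carbon. With no readable step at hand, no step beyond the scatter is expected, the estimated step being a step that the limit leaves unreadable from compound 3 to compound 4. Compound 4 is estimated at 200000 nM, between 80000 nM and 400000 nM.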

Compound 4, half-maximal cytotoxic concentration: > 122000 nM
Compound 4 gave a limit, no number (the forecaster's own chance of this, stated with the estimate: 85%); the middle value lies beyond the limit too.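

For the compounds shown here, compound 4, like compound 1, compound 2 and compound 3, gives only a limit, so no step among them can be read. The compounds shown leave open whether any of these changes shifts the read-out in this assay at all.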